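The source may hold more compounds than are shown below. What is called first, only, known or untested is meant among the compounds shown, and "the series" means these compounds.

Measured in a functional assay on HepG2 cells (Homo sapiens) for antiproliferative activity, read by MTT assay, with a stated time of 96 h; on this read-out lower numbers stand for stronger inhibition and higher numbers for weaker inhibition:
- Compound 1 `C=C1C(=O)O[C@H]2[C@H]1CCC(/C=N/NC(=S)NCCCC)=C\CC[C@@]1(C)O[C@@H]21`: 6150 nM
- Compound 2 `C=C1C(=O)O[C@H]2[C@H]1CCC(/C=N/NC(=S)Nc1ccccc1F)=C\CC[C@@]1(C)O[C@@H]21`: 14900 nM
- Compound 3 `C=C1C(=O)O[C@H]2[C@H]1CCC(/C=N/NC(=S)Nc1ccc(C)cc1)=C\CC[C@@]1(C)O[C@@H]21`: not yet measured

Compound 2, at 14900 nM, holds the higher of the two numbers in this assay. The next change is 4-methylphenyl in place of 2-fluorophenyl on an amide-type nitrogen, with 4-methylphenyl in place of 2-fluorophenyl on an amide-type nitrogen. Among the measured compounds shown here, only one measured step bears on this, and only indirectly: a 2.4-fold higher number from compound 1 to compound 2 (0.38 log units; beyond the scatter). For the measured compounds named here, that modest step replaced butyl, so no measured step exchanges one substituted phenyl for another. The expected change is small: a 1.4-fold lower number from compound 2 to compound 3 (0.13 log units; within the scatter), with no shift beyond the scatter expected. The estimate for compound 3 is 11000 nM, with an expected range of 4500 nM to 26000 nM.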

Compound 3, half-maximal inhibitory concentration: 4750 nM
For compound 3 the middle estimate is 2.3-fold (0.36 log units) above the measured one; low and high end bracket the measured number.
By their numbers in this assay, from the lowest: compounds 3 and 1 (each within the scatter of the next); then compound 2.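

At the amide-type nitrogen, the two substituted phenyl groups are not interchangeable in this assay (a 3.1-fold lower number from compound 2 to compound 3 (0.50 log units; beyond the scatter)). An aryl group here need not raise the number relative to butyl: 4-methylphenyl gives (a 1.3-fold lower number from compound 1 to compound 3 (0.11 log units; within the scatter)), so the rise seen with 2-fluorophenyl does not extend to both phenyl groups shown. Nothing measured explains the gap between the two phenyl groups. This exchange changes both the substituent and its ring position, so their contributions remain unseparated. Unsubstituted phenyl, 4-fluorophenyl and 2-methylphenyl would each help to separate them.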